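Notes on the amide substituent step to compound 3

The source may hold more compounds than are shown below. What is called first, only, known or untested is meant among the compounds shown, and "the series" means these compounds.

Compound 2 `C=CC1=C(C(=O)NCC(C)C)C(c2ccc(OC)cc2)OC1` is measured in a functional assay on HeLa cells (Homo sapiens) for cytotoxicity, read by MTT assay, with a stated time of 24 h; a higher number here means a weaker inhibitor, a lower number a stronger inhibitor. In this assay compound 2 gives > 100000 nM, which is a limit of the assay and not a number. Compound 1 `C=CC1=C(C(=O)NCc2ccc(Cl)cc2)C(c2ccc(OC)cc2)OC1` carries 4-chlorophenyl where compound 2 carries isopropyl on a saturated chain carbon bound to an amide-type nitrogen. In this assay compound 1 gives > 100000 nM, likewise a limit. The step that the two limits leave unreadable from compound 1 to compound 2 therefore cannot be read, and the limit of > 100000 nM in this assay, at which 2 of the 2 values shown sit, is all the shown numbers offer. Compound 2 thus stands at the limit, with no readable measured step placing it relative to anything else.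

Compound 3 `C=CC1=C(C(=O)Nc2ccc(OCC)cc2)C(c2ccc(OC)cc2)OC1` differs from compound 2 by 4-ethoxyphenyl in place of isobutyl on an amide-type nitrogen. No measured step touches the amide-type nitrogen itself, and the one step shown, on the saturated chain carbon bound to that nitrogen, is unreadable. Nothing here supports an expectation of a shift in this assay beyond the scatter, and the most likely outcome for compound 3 is that this assay again returns only a limit. Compound 3 is therefore expected near 100000 nM, within 30000 nM to 300000 nM. The expected step of a number no higher from compound 2 to compound 3 (the limit leaves the size open) is close to none.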

Compound 3, half-maximal inhibitory concentration: > 100000 nM
Compound 3: only a limit was reported (the forecaster's own chance of this, stated with the estimate: 80%); the middle value sits exactly at the limit.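

In this assay compound 3 gives > 100000 nM, a limit of the assay and not a number. The steps linking compound 3 to compound 1 and compound 2 therefore cannot be read, and the values offer only this: the limit of > 100000 nM in this assay, at which 3 of the 3 values shown sit.

The compounds shown leave open whether any substituent on the amide-type nitrogen of the shared core gives a readable value in this assay.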